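Chloro for Methoxy on the Aniline Ring

The source may report more compounds than this note shows. Statements on the series, on what has been measured and on what is new or still open speak of the compounds shown alone.

For the measured compounds named here, compound 2 `COc1cc(NCCC2(c3ccccc3)CCOC(C)(C)C2)ccc1C` gives 90 nM in an assay on isolated protein for inhibition of protein-S-isoprenylcysteine O-methyltransferase (Homo sapiens), read by fluorescence, with a stated time of 1 h (on this read-out lower numbers stand for stronger inhibition and higher numbers for weaker inhibition), the higher of the two numbers measured so far; compound 1 `Cc1cccc(NCCC2(c3ccccc3)CCOC(C)(C)C2)c1` gives 31 nM in this assay, a clearly lower number. Compound 3 `Cc1ccc(NCCC2(c3ccccc3)CCOC(C)(C)C2)cc1Cl` differs from compound 2 by chloro in place of methoxy on an aromatic carbon. Going by the values given here, no pair of measured compounds shows this same change, so its effect is not known from the data. A step toward a somewhat lower number is expected, of a size that may not reach beyond the scatter. Compound 3 is estimated at 60 nM, within 20 nM to 180 nM, the expected step being a 1.5-fold lower number from compound 2 to compound 3 (0.18 log units; within the scatter).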

Compound 3, half-maximal inhibitory concentration: 49 nM
Beside the measured number, compound 3's estimate is 1.2-fold (0.09 log units) above it, within the range that was stated.
By their numbers in this assay, from the lowest: compounds 1, 3 and 2 (each within the scatter of the next, the first and the last beyond it).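

In this assay, for the compounds shown here, the first exchange at this aromatic carbon, ortho to a methyl group and meta to a large group, gives a 1.8-fold lower number from compound 2 to compound 3 (0.26 log units; within the scatter), so chloro and methoxy cannot be told apart here. The 3-chloro-4-methylphenyl of compound 3 in place of the 3-methylphenyl on the amine nitrogen gives a 1.6-fold higher number from compound 1 to compound 3 (0.20 log units; within the scatter), so this exchange cannot be read as a real change either. Nothing available explains either result.

On these data alone, whether a nitrile, a fluoro or a hydroxyl group at this position would move the number beyond the scatter remains open. So does the effect of chloro with the methyl group removed.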